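A few compounds are considered here, and "the series" means these few. Any claim that something is new, unique, unknown or untested is made for them only; others in the source may bear on it.

Of the compounds shown here, three built on one shared core have been tested in a functional assay on MGC-803 cells (Homo sapiens) for inhibition; a higher number here means a weaker inhibitor, a lower number a stronger inhibitor. Compound 1 `CCN(CC)CCNC(=O)CC(CC(=O)NC1Cc2ccccc2C1)c1ccc(Cl)cc1` gives only a limit of the assay, > 100000 nM. Compound 2 `O=C(CC(CC(=O)NC1Cc2ccccc2C1)c1ccc(Cl)cc1)NCCN1CCCC1` likewise reaches only a limit, > 100000 nM. Compound 3 `O=C(CC(CC(=O)NC1Cc2ccccc2C1)c1ccccc1)NCCN1CCCC1` also stops at a limit, > 100000 nM. All three values are summarised by the limit of > 100000 nM in this assay, at which 3 of the 3 values shown sit. The step that the two limits leave unreadable from compound 1 to compound 2, pyrrolidin-1-yl in place of diethylamino on a saturated chain carbon, two bonds along the chain from an amide-type nitrogen, cannot be read, and neither can a step that the two limits leave unreadable from compound 2 to compound 3, hydrogen in place of chloro on an aromatic carbon. Compound 2 thus stands only at a limit, with no number of its own.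

Compound 4 `CCN(C(=O)CC(CC(=O)NCCN1CCCC1)c1ccc(Cl)cc1)C1Cc2ccccc2C1` differs from compound 2 in one place: ethyl in place of hydrogen on an amide-type nitrogen. Within the data shown here, neither measured step changes this amide-type nitrogen, and both are unreadable in any case, so no measured step bears on the size or direction of this change. Because every measured compound sits at the limit described by the limit of > 100000 nM in this assay, at which 3 of the 3 values shown sit, the expectation is that compound 4 also sits at or near it. Compound 4 is therefore estimated at 100000 nM, in a range from 20000 nM to 300000 nM. The step this estimate implies, a number no higher from compound 2 to compound 4 (the limit leaves the size open), is expected to stay within the scatter.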

Compound 4, half-maximal inhibitory concentration: 55500 nM
Estimate against measurement, compound 4: 1.8-fold (0.26 log units) above, within the range that was stated.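

Among these compounds, compound 4 is the first compound in this set to give a number rather than a limit in this assay, at 55500 nM, so ethyl in place of hydrogen on this amide-type nitrogen, whose other neighbours are a carbonyl carbon and a saturated ring carbon, yields the first step that can be read at all, though only as a floor: an at least 1.8-fold lower number from compound 2 to compound 4 (0.25 log units; that floor lies within the scatter). Among the compounds shown here, compound 2 itself remains at a limit, > 100000 nM, so the true size of this step stays unknown, and the earlier steps still cannot be read. What the result adds is that this nitrogen tolerates an ethyl group without the number moving past the limit, while the rest of the set stays where it was: the limit of > 100000 nM in this assay, at which 3 of the 4 values shown sit.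

On these data alone, whether a methyl group or a longer chain such as propyl on this nitrogen would lower the number further remains open, as does the effect of a benzyl group there. Also open, as far as these compounds go, is whether ethyl at this place would give a number with diethylamino in place of pyrrolidin-1-yl, or with hydrogen in place of chloro.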